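The source may report more compounds than this note shows. Statements on the series, on what has been measured and on what is new or still open speak of the compounds shown alone.

Three compounds in this set share one core and differ at two places. Compound 1 `c1ccc2c(-c3cn4ccnc4c(-c4ccc5ncn(C6CCCCC6)c5c4)n3)cccc2c1` carries naphthalen-1-yl at one end and cyclohexyl at the other; in a functional assay on SR cells (Homo sapiens) for inhibition, read by sulforhodamine B assay, with a stated time of 48 h, tested at 10 uM (on this read-out higher numbers stand for more inhibition at the one concentration tested (going by the name of the read-out) and lower numbers for less inhibition), compound 1 gives 6.92%. Compound 2 `CCc1ccc(-c2cn3ccnc3c(-c3ccc4ncn(Cc5ccccc5)c4c3)n2)cc1` carries an ethylphenyl group and a benzyl group, and in this assay compound 2 gives 49.9%. Compound 3 `O=Cc1ccc(-c2cn3ccnc3c(-c3ccc4ncn(Cc5ccccc5)c4c3)n2)cc1` keeps the benzyl group but bears a formyl group in place of the ethyl, and in this assay compound 3 gives 47.5%. The step of a number 2.4 percentage points lower from compound 2 to compound 3 (within the scatter) shows that swapping ethyl for formyl changed little. Compound 3 stands second highest of the three numbers, close to compound 2 and far above compound 1.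

Compound 4 `c1ccc(Cn2cnc3ccc(-c4nc(-c5cccc6ccccc56)cn5ccnc45)cc32)cc1` is the next step from compound 3: naphthalen-1-yl in place of 4-formylphenyl on an aromatic carbon. For the measured compounds named here, no measured step covers exactly this change. Going by the values given here, the only clue is compound 1, which also carries naphthalen-1-yl but with cyclohexyl instead of benzyl, and its low value cannot be separated into the two changes. The expectation is therefore a drop of moderate size, a number 19.5 percentage points lower from compound 3 to compound 4 (beyond the scatter), with wide uncertainty. Compound 4 is estimated at 28%, within a range from 5% to 55%.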

Compound 4, a percentage reported as inhibition, at one concentration (the size of the read-out at that concentration, not a potency): 12.4%
For compound 4 the middle estimate is 15.6 percentage points above the measured one; the measured number falls inside the stated range.
By their numbers in this assay, from the lowest: compounds 1 and 4 (each within the scatter of the next); then compounds 3 and 2 (each within the scatter of the next).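

In this assay the group on this aromatic carbon proves to matter a great deal: with benzyl kept at the other end, naphthalen-1-yl in place of 4-formylphenyl gives a number 35.1 percentage points lower from compound 3 to compound 4 (beyond the scatter) and naphthalen-1-yl in place of 4-ethylphenyl gives a number 37.5 percentage points lower from compound 2 to compound 4 (beyond the scatter) as the result. Compound 1 had carried two differences at once, and the new compound pulls them apart: with naphthalen-1-yl held fixed, benzyl in place of cyclohexyl on an aromatic nitrogen gives a number 5.5 percentage points higher from compound 1 to compound 4 (within the scatter) and so makes no clear difference in this pair. Nothing measured here says why the naphthalen-1-yl compounds sit so low.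

The compounds shown leave open whether a 4-aminophenyl or 4-carboxyphenyl group on this carbon would keep the inhibition seen with the 4-ethylphenyl and 4-formylphenyl groups. They also leave open whether cyclohexyl would match benzyl on the nitrogen when one of those two phenyl groups sits at the other end, since the match so far holds only alongside naphthalen-1-yl.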